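Chloro in place of carbamoyl on the shared core

The compounds below may be only part of what the source reports. "The series", "measured", "known", "first", "only" and "open" are said of these compounds alone.

Compound 2 `NC(=O)c1ccccc1C1Cc2nccn2C1` carries a carbamoyl group on its aromatic ring. In a functional assay on CHO cells for agonist activity at Alpha-1D adrenergic receptor (Homo sapiens), read by FLIPR and calcium flux (on this read-out lower numbers stand for an effect already at smaller amounts and higher numbers for an effect only at larger amounts of compound), compound 2 has no result, reported as "not determined" (no result reported), so it stands on no number of its own. Among the measured compounds shown here, the only value in sight comes from compound 1 `Clc1ccc(C2Cc3nccn3C2)cc1`, which bears a chloro group instead. In this assay compound 1 gives only a limit, > 10000 nM. That limit is all there is to go on: the limit of > 10000 nM in this assay, at which 1 of the 2 values shown sits.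

Compound 3 `Clc1ccccc1C1Cc2nccn2C1` is the unmeasured partner of compound 2. The change is chloro in place of carbamoyl on an aromatic carbon. For the measured compounds named here, no measured step exists between the two, and the chloro group is shared with compound 1; the size of the step from compound 2 to compound 3 in this assay cannot be read from the data, and no direction beyond the scatter can be claimed. Compound 3 is expected to give about 15000 nM, within a range from 3000 nM to 100000 nM, because compound 1 with the same chloro group reached only > 10000 nM.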

Compound 3, half-maximal effective concentration: 364 nM
Compound 3: middle estimate off by 41-fold (1.61 log units), on the high side; the measured number lies below the stated range.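

No step can be read from compound 2 to compound 3, since compound 2 has no number of its own in this assay. The compounds shown leave open how carbamoyl and chloro compare at this place on the shared core in this assay.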